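Working notes: the step from compound 3 to compound 4

A few compounds are considered here, and "the series" means these few. Any claim that something is new, unique, unknown or untested is made for them only; others in the source may bear on it.

For the measured compounds named here, in a functional assay on HeLa cells (Homo sapiens) for cytotoxicity, read by sulforhodamine B assay, with a stated time of 72 h (on this read-out higher numbers stand for weaker inhibition and lower numbers for stronger inhibition), compound 3 `COc1ccccc1/C=C/C(=O)Nc1cc(OC)c(OC)c(OC)c1` gives 6100 nM, the lowest number so far. The nearest number comes from compound 1 `COc1cc(NC(=O)/C=C/c2cccc(O)c2)cc(OC)c1OC`, at 18700 nM. Compound 2 `COc1cc(NC(=O)/C=C/c2ccccc2)cc(OC)c1OC` returns only a limit of the assay, > 50000 nM.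

The next structure is compound 4 `COc1cc(NC(=O)/C=C/c2ccc(O)cc2)cc(OC)c1OC`, and the change is 4-hydroxyphenyl in place of 2-methoxyphenyl on a double-bonded chain carbon bound to a double-bonded chain carbon. In words, it is 4-hydroxyphenyl in place of 2-methoxyphenyl on a double-bonded chain carbon bound to a double-bonded chain carbon.

Going by the values given here, no measured compound carries the 4-hydroxyphenyl group, so the evidence is indirect. The closest comparison is a 3.1-fold lower number from compound 1 to compound 3 (0.49 log units; beyond the scatter), which also exchanges a hydroxy-bearing ring for the 2-methoxyphenyl ring. Compound 4 would reverse that kind of exchange. Two further steps show that substitution on this ring matters: an at least 2.6-fold higher number from compound 1 to compound 2 (0.42 log units; beyond the scatter) and an at least 8.1-fold lower number from compound 2 to compound 3 (0.91 log units; beyond the scatter). Compound 4 is therefore expected to sit nearer compound 1 at 18700 nM than compound 3, with a higher number in this assay. The expected change is a 3.3-fold higher number from compound 3 to compound 4 (0.52 log units; beyond the scatter), similar in size to the closest comparison.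

The estimate for compound 4 is 20000 nM, with an expected range of 8000 nM to 50000 nM.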

Compound 4, half-maximal inhibitory concentration: > 50000 nM
Compound 4: no number, only a limit; the forecaster's own chance of this, stated with the estimate: 20%; middle value at least 2.5-fold (0.39 log units) from the limit.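

In this assay, the 3-hydroxyphenyl and 4-hydroxyphenyl groups are not interchangeable at this place on the chain: the exchange gives an at least 2.6-fold higher number from compound 1 to compound 4 (0.42 log units; beyond the scatter), so carrying a hydroxy group on the ring does not by itself give a readable number. The exchange of 2-methoxyphenyl for 4-hydroxyphenyl gives an at least 8.1-fold higher number from compound 3 to compound 4 (0.91 log units; beyond the scatter), which shows that the lead held by compound 3 does not survive this change, and that compound 4 joins compound 2 rather than compound 1 in the series. The step between compound 2 and compound 4 cannot be read, and no effect of adding the hydroxy group to the phenyl ring can be stated, because both compounds stand at a limit rather than a number: the limit of > 50000 nM in this assay, at which 2 of the 4 values shown sit.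

The compounds shown do not separate the effect of the methoxy group in compound 3 from the effect of where it sits on the ring, as 2-methoxyphenyl is the only methoxy-bearing ring at this place. As far as these compounds go, how a fluorine or an amine on this ring, or a longer chain leading to the ring, would read in this assay also remains open.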